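Furan-3-yl for thiophen-3-yl on a weakly active methylamino nucleoside

The compounds below may be only part of what the source reports. "The series", "measured", "known", "first", "only" and "open" are said of these compounds alone.

Compound 1 `CNc1ncnc2c1c(-c1ccsc1)cn2[C@@H]1O[C@H](CO)[C@@H](O)[C@H]1O` gives only a limit, not a number, in a functional assay on K562 cells (Homo sapiens), read by MTT assay, with a stated time of 72 h; on this read-out lower numbers stand for stronger inhibition and higher numbers for weaker inhibition: > 20000 nM. Compound 1 therefore sits at the limit of > 20000 nM in this assay, at which 1 of the 3 values shown sits, the weakest point of the values shown. Compound 2 `COc1ncnc2c1c(-c1ccco1)cn2[C@@H]1O[C@H](CO)[C@@H](O)[C@H]1O` gives 60 nM in this assay, and compound 3 `C#Cc1cn([C@@H]2O[C@H](CO)[C@@H](O)[C@H]2O)c2ncnc(N(C)C)c12` gives 110 nM; both carry other groups on the shared core, so neither forms a single-point step to compound 1 or compound 4. Compound 4 `CNc1ncnc2c1c(-c1ccoc1)cn2[C@@H]1O[C@H](CO)[C@@H](O)[C@H]1O` differs from compound 1 by furan-3-yl in place of thiophen-3-yl on an aromatic carbon. Among the measured compounds shown here, no measured step of this kind is available, so the change from compound 1 to compound 4 is expected to stay within the scatter or move only modestly. Compound 4 is estimated at 15000 nM, between 2000 nM and 40000 nM, an expected step of an at least 1.3-fold lower number from compound 1 to compound 4 (0.12 log units; that floor lies within the scatter).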

Compound 4, half-maximal inhibitory concentration: > 20000 nM
Compound 4: no number, only a limit; the forecaster's own chance of this, stated with the estimate: 50%; middle value at least 1.3-fold (0.12 log units) away from the limit.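

Compound 1 and compound 4 both give only limits in this assay, so no step between them can be read: the limit of > 20000 nM in this assay, at which 2 of the 4 values shown sit.

The compounds shown leave open whether furan-3-yl and thiophen-3-yl differ at all on this shared core.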